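This account rests on a few compounds, and the source may have more. Where it says the series, first, only, none or still open, it means among the compounds named here.

Measured so far:
Compound 1, `O=C(Nc1cc(C(F)(F)F)cc(C(F)(F)F)c1)C1CCc2ccccc2N1C(=O)c1ccccc1Cl`: 8040 nM
Compound 2, `CCC(=O)N1c2ccccc2CCC1C(=O)Nc1cc(C(F)(F)F)cc(C(F)(F)F)c1`: 8540 nM
Compound 3, `O=C(Nc1cc(C(F)(F)F)cc(C(F)(F)F)c1)C1CCc2ccccc2N1`: 8120 nM

All three numbers come from a functional assay on PC-3 cells (Homo sapiens) for cytotoxicity, read by sulforhodamine B assay, with a stated time of 72 h; on this read-out lower numbers stand for stronger inhibition of growth and higher numbers for weaker inhibition of growth. Compound 3 stands within the scatter of both other compounds, so no one of the three can be called stronger or weaker. Compound 4, `O=C(Nc1cc(C(F)(F)F)cc(C(F)(F)F)c1)C1CCc2ccccc2N1C(=O)c1ccccc1`, is not yet measured; it differs from compound 3 by benzoyl in place of hydrogen on a nitrogen on an aromatic ring in a ring. Among the measured compounds shown here, two measured steps bear on this change, both touching the same nitrogen: a 1.0-fold higher number from compound 1 to compound 3 (0.00 log units; within the scatter) and a 1.1-fold lower number from compound 2 to compound 3 (0.02 log units; within the scatter). Neither removal of an acyl group moved the number beyond the scatter, so adding a benzoyl there is expected to change little in either direction: a 1.0-fold higher number from compound 3 to compound 4 (0.00 log units; within the scatter). Compound 4 is therefore estimated at 8200 nM, with a range from 4000 nM to 16000 nM.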

Compound 4, concentration for 50% growth inhibition: 3500 nM
Estimate against measurement, compound 4: 2.3-fold (0.37 log units) above; the measured number lies below the stated range.
By their numbers in this assay, from the lowest: compound 4; then compounds 1, 3 and 2 (each within the scatter of the next).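

In this assay an acyl group on this nitrogen can matter after all: benzoyl in place of hydrogen gives a 2.3-fold lower number from compound 3 to compound 4 (0.37 log units; beyond the scatter) here, though propanoyl and (2-chlorophenyl)carbonyl left the number within the scatter of the free nitrogen. The group on the carbonyl carbon counts, as phenyl in place of ethyl gives a 2.4-fold lower number from compound 2 to compound 4 (0.39 log units; beyond the scatter) and hydrogen in place of chloro on the aromatic carbon gives a 2.3-fold lower number from compound 1 to compound 4 (0.36 log units; beyond the scatter) among these compounds. Nothing measured here explains this difference. Open, as far as these compounds go, is whether a methoxy group or an amine on that phenyl ring would follow hydrogen or chloro, and whether a longer chain in place of ethyl would behave like phenyl.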